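This account rests on a few compounds, and the source may have more. Where it says the series, first, only, none or still open, it means among the compounds named here.

For the measured compounds named here, in a functional assay on BT-474 cells (Homo sapiens) for inhibition, read by CellTiter-Glo, with a stated time of 72 h (on this read-out higher numbers stand for weaker inhibition and lower numbers for stronger inhibition), compound 1 (`Cc1cc(Nc2ncnc3cc(O)c(NC(=O)/C=C/[C@H]4CCCN4C)cc23)ccc1Oc1ccn2ncnc2c1`) gives 2.4 nM and belongs to the low end of the three numbers known so far. Compound 2 (`C=CC(=O)Nc1cc2c(Nc3ccc(Oc4cc5nncn5cn4)c(C)c3)ncnc2cc1OCC`) gives 4.69 nM in this assay and lies within the scatter of compound 1. Compound 3 (`Cc1cc(Nc2ncnc3cc(O)c(NC(=O)/C=C/[C@H]4CCCN4C)cc23)ccc1Oc1cnn2cnnc2c1`) gives 20.8 nM in this assay and stands apart from that pair. Compound 4 (`Cc1cc(Nc2ncnc3cc(O)c(NC(=O)/C=C/[C@H]4CCCN4C)cc23)ccc1Oc1ccc2nccn2c1`) has not yet been measured. It differs from compound 1 by a group of 9 heavy atoms (7 carbon, 2 nitrogen; one five-membered aromatic ring with 2 hetero atoms, one six-membered aromatic ring with 1 hetero atom) in place of a group of 9 heavy atoms (6 carbon, 3 nitrogen; one five-membered aromatic ring with 3 hetero atoms, one six-membered aromatic ring with 1 hetero atom), on an oxygen on an aromatic ring and so carries 2 hydrogen-bond acceptors in that group where compound 1 carries 3.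

Going by the values given here, only one measured step touches this group on the oxygen, namely an 8.7-fold higher number from compound 1 to compound 3 (0.94 log units; beyond the scatter) for another exchange of a carbon and a nitrogen within it. That single step shows that the number can move with such an exchange, but it swaps a different ring atom and does not fix the direction for compound 4. Among the compounds with values here, a modest move towards a higher number, meaning weaker inhibition, is the likelier outcome, and no larger than that step. Thus a 3.3-fold higher number from compound 1 to compound 4 (0.52 log units; beyond the scatter) is the expected step in this assay here. For compound 4 the estimated value is 8 nM in this assay with an expected range from 2 nM to 30 nM on this reading.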

Compound 4, half-maximal inhibitory concentration: 5.22 nM
Beside the measured number, compound 4's estimate is 1.5-fold (0.19 log units) above it; the range from low to high includes it.
By their numbers in this assay, from the lowest: compounds 1, 2 and 4 (each within the scatter of the next, the first and the last beyond it); then compound 3.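

In this assay the group on the oxygen on an aromatic ring now has two exchanges on record, and a 2.2-fold higher number from compound 1 to compound 4 (0.34 log units; beyond the scatter) and an 8.7-fold higher number from compound 1 to compound 3 (0.94 log units; beyond the scatter) are steps in the same direction away from compound 1. The number does not follow the nitrogen count of this group: the group of compound 1 holds 3 nitrogens and gives the lowest value of these three compounds, while the groups with 2 and with 4 nitrogens both give higher values. The step of a 4.0-fold lower number from compound 3 to compound 4 (0.60 log units; beyond the scatter) shows in addition that the two altered groups do not sit at one level, with compound 4 remaining closer to compound 1 than compound 3 does.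

Nothing measured here accounts for these differences. For the compounds shown here, with only three such groups compared on this core, it stays open how the number would respond to an amine or a fluorine atom attached to the group, or to a plain phenyl ring in its place.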